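Acyloxymethyl phosphonate esters: blood half-life of a heteroaryl change

The compounds below may be only part of what the source reports. "The series", "measured", "known", "first", "only" and "open" are said of these compounds alone.

Measured compounds in an ADME assay on blood (Homo sapiens) for pharmacokinetics; on this read-out higher numbers stand for a longer-lived compound and lower numbers for a shorter-lived compound:
- compound 1 `COC(=O)CCNC(=O)[C@@H]1O[P@](=O)(OCOC(=O)c2ccnn2C)OCC1(C)C`: a limit of the assay, < 0.16 h
- compound 2 `COC(=O)CCNC(=O)[C@@H]1O[P@](=O)(OCOC(=O)c2ocnc2C)OCC1(C)C`: 0.27 h
- compound 3 `CC(C)(C)C(=O)OCO[P@@]1(=O)OCC(C)(C)[C@H](C(=O)NCCC(=O)OCCc2ccccn2)O1`: a limit of the assay, < 0.16 h

Compound 2 holds the only number shown in this assay; the other two values are limits, and both sit at the limit of < 0.16 h in this assay, at which 2 of the 3 values shown sit. Of compound 1 nothing beyond its limit is known. Among the compounds with values here, of compound 3 likewise only its limit is known, and no step links it to any other compound here.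

The step from compound 2 to compound 4 `COC(=O)CCNC(=O)[C@@H]1O[P@](=O)(OCOC(=O)c2scnc2C)OCC1(C)C` is 4-methyl-1,3-thiazol-5-yl in place of 4-methyl-1,3-oxazol-5-yl on a carbonyl carbon. Within the data shown here, the one measured step that bears on it is the change of the heteroaryl group on the same carbonyl carbon, an at least 1.6-fold higher number from compound 1 to compound 2 (0.22 log units; that floor lies within the scatter); its floor lies within the scatter, so even that step gives no firm direction. A change from a five-membered ring with two hetero atoms to another such ring, both with no donors and two acceptors, is therefore expected to leave this assay unchanged beyond the scatter: the step of a 1.1-fold higher number from compound 2 to compound 4 (0.05 log units; within the scatter) is the estimate. Compound 4 is thus expected to give about 0.3 h, within 0.12 h to 0.75 h, with a fair chance that the assay again reports only a limit.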

Compound 4, half-life: < 0.16 h
Compound 4: only a limit was reported; the forecaster's own chance of this, stated with the estimate: 35%; at least 1.8-fold (0.27 log units) between middle value and limit.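

In this assay, 4-methyl-1,3-thiazol-5-yl in place of 4-methyl-1,3-oxazol-5-yl on this carbonyl carbon gives an at least 1.6-fold lower number from compound 2 to compound 4 (0.22 log units; that floor lies within the scatter), so the readable floor fixes no firm direction, although the true step may be larger. Compound 2 remains the only compound with a number among these heteroaryl esters, while compound 1 and compound 4 both end at a limit, so exchanging one ring oxygen for sulfur, with the counts of heavy atoms, donors and acceptors unchanged, does not preserve a readable number. The step from compound 1 to compound 4 cannot be read, and the floor of the read-out now holds most of the values shown: the limit of < 0.16 h in this assay, at which 3 of the 4 values shown sit.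

As far as these compounds go, how far compound 4 lies past its limit remains open, as does whether its step from compound 2 exceeds the scatter. Also open, from the compounds shown here alone, is how this assay responds to a phenyl or cyclopropyl group on this carbonyl carbon, or to a carboxylic acid in place of the methyl ester on the shared core.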